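The source may report more compounds than this note shows. Statements on the series, on what has been measured and on what is new or still open speak of the compounds shown alone.

For the measured compounds named here, compound 1, with the structure `N[C@@H](COP(=O)(O)OCCCOC(=O)CCc1ccccc1OCc1cccc(Oc2ccccc2)c1)C(=O)O`, is one of three compounds measured in an assay on cells for activation of probable G-protein coupled receptor 34 (Mus musculus), with a stated time of 1 h (on this read-out lower numbers stand for smaller maximal responses and higher numbers for larger maximal responses), where compound 1 gives 0.48. That places compound 1 second highest of the three. The highest number belongs to compound 3, `N[C@@H](COP(=O)(O)OCCCOC(=O)CCc1ccccc1OCc1cccc(Oc2cccc(Cl)c2)c1)C(=O)O`, which in this assay gives 0.53; the step a number 0.050 higher from compound 1 to compound 3 (within the scatter) lies within the usual scatter, so the two cannot be told apart. The lowest belongs to compound 2, `Cc1ccccc1Oc1cccc(COc2ccccc2CCC(=O)OCCCOP(=O)(O)OC[C@H](N)C(=O)O)c1`, which gives 0.28; the step a number 0.20 lower from compound 1 to compound 2 (beyond the scatter) is a modest loss, and the reverse comparison a number 0.25 higher from compound 2 to compound 3 (beyond the scatter) shows a modest gain.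

The next compound, compound 4, has the structure `N#Cc1ccc(Oc2cccc(COc3ccccc3CCC(=O)OCCCOP(=O)(O)OC[C@H](N)C(=O)O)c2)cc1`. Compared with compound 1 the change is cyano in place of hydrogen on an aromatic carbon; read one bond further out, phenoxy becomes 4-cyanophenoxy. Going by the values given here, the nearest precedent is compound 3, where a chloro on the same outer ring moved the number by only a number 0.050 higher from compound 1 to compound 3 (within the scatter). Among the compounds with values here, the methyl of compound 2 sits on the same ring and gave the larger drop a number 0.20 lower from compound 1 to compound 2 (beyond the scatter), but no step with a cyano group is available. On balance the expected step is small: a number 0.020 higher from compound 1 to compound 4 (within the scatter), likely within the scatter. Compound 4 is therefore estimated at 0.5, with a range from 0.35 to 0.65.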

Compound 4, intrinsic activity: the largest response reached, as a fraction of the reference agonist's: 0.041
Compound 4: the middle estimate sits 0.46 above what was measured; the measured number lies below the stated range.
By their numbers in this assay, from the lowest: compound 4; then compound 2; then compounds 1 and 3 (each within the scatter of the next).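

Cyano in place of hydrogen on this outer ring, turning phenoxy into 4-cyanophenoxy, gives the largest step from compound 1 so far in this assay, a number 0.44 lower from compound 1 to compound 4 (beyond the scatter), so this ring does not accept every added group equally. Compound 3 kept a number within the scatter of compound 1, yet 4-cyanophenyl in place of its 3-chlorophenyl gives a number 0.49 lower from compound 3 to compound 4 (beyond the scatter), so carrying a group on this ring does not by itself preserve the response. Even compound 2, the lowest of the earlier compounds, stands apart from compound 4, with a number 0.24 lower from compound 2 to compound 4 (beyond the scatter), which leaves compound 4 with the smallest maximal response of the four.

The three substituted compounds differ in both the group and its place on the ring, so these results cannot separate the effect of cyano itself from the effect of its position, and a carboxylic acid or an amide at the same position would help to test how specific the loss is. Nothing available here explains why the cyano compound falls so far.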